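Enlarging the ring on the amide-type nitrogen

The source may report more compounds than this note shows. Statements on the series, on what has been measured and on what is new or still open speak of the compounds shown alone.

Compound 1, `CC(C)(C)C(=O)N(CCCCCCN1C[C@H](O)[C@@H](O)[C@H](O)[C@H]1CO)c1cc(F)ccc1F`, gives > 500000 nM in an ADME assay on BHK cells (Mesocricetus auratus) for cytotoxicity, read by MTT assay; a lower number here means that less compound is tolerated, a higher number that more compound is tolerated.
Compound 2, `CC(C)(C)C(=O)N(CCCCCCN1C[C@H](O)[C@@H](O)[C@H](O)[C@H]1CO)C1CCCCCC1`, gives > 500000 nM in this assay.

Both numbers are limits of the assay rather than measured values. For compound 1 the figure > 500000 nM is such a limit. For compound 2 the figure > 500000 nM is likewise a limit. Within the data shown here, compound 2 therefore stands at the upper edge of what this assay can report, together with the only other compound measured. Among the measured compounds shown here, the single step between measured compounds, a step that the two limits leave unreadable from compound 1 to compound 2, cannot be sized because both of its ends sit at the limit of > 500000 nM in this assay, at which 2 of the 2 values shown sit.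

Compound 3, `CC(C)(C)C(=O)N(CCCCCCN1C[C@H](O)[C@@H](O)[C@H](O)[C@H]1CO)C1CCCCCCC1`, differs from compound 2 in one place: cyclooctyl in place of cycloheptyl on an amide-type nitrogen. For the measured compounds named here, the only measured step that bears on it is the unreadable one from the 2,5-difluorophenyl to the cycloheptyl compound, so there is no basis for expecting a readable step in this assay in either direction. The expectation is that compound 3 again reaches the limit of this assay. Compound 3 is therefore estimated at 600000 nM, with a range from 250000 nM to 1500000 nM. The expected step is a step that the limit leaves unreadable from compound 2 to compound 3.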

Compound 3, half-maximal cytotoxic concentration: 208000 nM
The estimate for compound 3 lay 2.9-fold (0.46 log units) above the measured number, and the stated range ends above it.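

Among these compounds, compound 3 is the first compound here to give a reading in this assay rather than a limit, which shows that the group on this amide-type nitrogen can change the result within the range the assay can report: the limit of > 500000 nM in this assay, at which 2 of the 3 values shown sit. Going from the seven-membered to the eight-membered ring, cyclooctyl in place of cycloheptyl, gives an at least 2.4-fold lower number from compound 2 to compound 3 (0.38 log units; beyond the scatter), so less of compound 3 is tolerated by the cells. Replacing the 2,5-difluorophenyl group with cyclooctyl gives an at least 2.4-fold lower number from compound 1 to compound 3 (0.38 log units; beyond the scatter), and both steps are only minimum sizes, leaving their true sizes unknown.

The compounds shown leave open whether the number keeps falling with a still larger carbon ring such as cyclodecyl, or whether a smaller one such as cyclohexyl stays at the limit. They also do not show what happens in this assay when the cyclooctyl ring carries an amine or a carboxylic acid, or when a straight octyl chain takes its place on the same nitrogen.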